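Swapping a cyclobutyl for a methoxyazetidine on the amide

The source may hold more compounds than are shown below. What is called first, only, known or untested is meant among the compounds shown, and "the series" means these compounds.

Measured so far in an ADME assay (Rattus norvegicus, strain Wistar Han) for pharmacokinetics; on this read-out lower numbers stand for narrower distribution and higher numbers for wider distribution into tissues:
compound 1 `CCn1c(-c2cnc(C)nc2)nc2c(N[C@H]3CCN(C(=O)C4CCC4)C3)ncnc21` — 0.5 L/kg
compound 2 `CCn1c(-c2ccc(C(F)(F)F)nc2)nc2c(O[C@H]3CCN(C(=O)N4CC(OC)C4)C3)ncnc21` — 0.2 L/kg
compound 3 `CCn1c(-c2ccc(C(F)(F)F)nc2)nc2c(O[C@H]3CCN(C(=O)C4CCOC4)C3)ncnc21` — 0.2 L/kg

Among these three, compound 1 stands highest, and both compound 2 and compound 3 lie below it by more than the usual scatter. Compound 2 and compound 3 share a core that differs from that of compound 1, so their lower numbers cannot be tied to any single change.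

Compound 4 `CCn1c(-c2cnc(C)nc2)nc2c(N[C@H]3CCN(C(=O)N4CC(OC)C4)C3)ncnc21` keeps the core of compound 1 and alters only the group on the carbonyl carbon: 3-methoxyazetidin-1-yl in place of cyclobutyl on a carbonyl carbon. Within the data shown here, the one measured step that resembles this is no change at the digits printed from compound 2 to compound 3 (within the scatter), where a ring attached through nitrogen gave way to a ring attached through carbon on that same carbonyl and nothing shifted beyond the scatter. That step went in the opposite direction to the present one, with a different ring, so it offers only loose guidance. On this basis the move from compound 1 to compound 4 is expected to yield no change beyond the scatter, shown as a 1.3-fold lower number from compound 1 to compound 4 (0.10 log units; within the scatter). Compound 4 is therefore estimated at 0.4 L/kg, within a range from 0.2 L/kg to 0.8 L/kg.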

Compound 4, volume of distribution: 0.7 L/kg
The estimate for compound 4 lay 1.8-fold (0.24 log units) below the measured number; low and high end bracket the measured number.
By their numbers in this assay, from the lowest: compounds 2 and 3 (each within the scatter of the next); then compounds 1 and 4 (each within the scatter of the next).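

In this assay, the exchange of cyclobutyl for 3-methoxyazetidin-1-yl on the carbonyl carbon gives a 1.4-fold higher number from compound 1 to compound 4 (0.15 log units; within the scatter) and so stays inside the usual spread of repeat measurements. This position on the core of compound 1 therefore accepts a ring holding a nitrogen, with a methoxy group attached, without a change that can be told apart from that spread. The earlier step at this carbonyl, no change at the digits printed from compound 2 to compound 3 (within the scatter), compared two rings that both carry a hetero atom, whereas the new step sets a ring of carbon only against one with a hetero atom, and no measurement shown here offers an explanation for the outcome.

The compounds shown leave open whether cyclobutyl and 3-methoxyazetidin-1-yl would also match on the core of compound 2, where the same carbonyl position has a different surrounding structure. They also leave open how this position would respond to quite different groups, such as an open-chain dimethylamino group or a ring bearing a carboxylic acid.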